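Cap exchange on compound 2

A few compounds are considered here, and "the series" means these few. Any claim that something is new, unique, unknown or untested is made for them only; others in the source may bear on it.

Among the measured compounds shown here, compound 2 `CN(C)c1ccc(C(=O)N[C@@H](CCCCCC(=O)NO)C(=O)Nc2cccc3cccnc23)cc1` holds the lowest number of the two measured so far: in a functional assay on MM96L cells (Homo sapiens) for antiproliferative activity (a lower number here means a stronger inhibitor, a higher number a weaker inhibitor), compound 2 gives 20 nM, whereas compound 1 `O=C(/C=C/c1ccccc1)N[C@@H](CCCCCC(=O)NO)C(=O)NCc1ccccc1` gives 460 nM, a gap beyond the scatter. Compound 3 `O=C(/C=C/c1ccccc1)N[C@@H](CCCCCC(=O)NO)C(=O)Nc1cccc2cccnc12` keeps the remainder of compound 2 and carries 2-phenylethenyl in place of 4-(dimethylamino)phenyl on a carbonyl carbon. For the measured compounds named here, no measured pair isolates this change; compound 1 and compound 2 differ in two places at once, so their values alone cannot size it. The expected step of a 3.0-fold higher number from compound 2 to compound 3 (0.48 log units; beyond the scatter) points towards a higher number, with wide uncertainty. Compound 3 is estimated at 60 nM, within 15 nM to 250 nM.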

Compound 3, half-maximal inhibitory concentration: 21 nM
Compound 3: middle estimate off by 2.9-fold (0.46 log units), on the high side; the measured number falls inside the stated range.
By their numbers in this assay, from the lowest: compounds 2 and 3 (each within the scatter of the next); then compound 1.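

In this assay, 2-phenylethenyl in place of 4-(dimethylamino)phenyl on a carbonyl carbon gives a step within the scatter (a 1.1-fold higher number from compound 2 to compound 3 (0.02 log units; within the scatter)), so with quinolin-8-yl on the amide-type nitrogen, these two groups are not told apart. At that nitrogen, quinolin-8-yl in place of benzyl gives a large step (a 22-fold lower number from compound 1 to compound 3 (1.34 log units; beyond the scatter)), the first single-place reading there. No measurement given here explains either step. Still open, on these data alone, is whether the carbonyl exchange stays within the scatter with benzyl on the nitrogen, and how a naphthalen-1-yl group there would compare with quinolin-8-yl.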